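A few compounds are considered here, and "the series" means these few. Any claim that something is new, unique, unknown or untested is made for them only; others in the source may bear on it.

Compound 1, `O=C(O)c1ccccc1-c1ccc(CCc2ncc(Cc3ccccc3F)[nH]2)cc1`, gives 177 nM in an in vitro functional assay on cells for agonist activity at Bombesin receptor subtype-3 (Homo sapiens), read by luminescence and calcium flux; a higher number here means that more compound is needed for the effect, a lower number that less compound is needed. Compound 2, `N#Cc1ccc(Cc2cnc(CCc3ccc(-c4ccccc4C(=O)O)cc3)[nH]2)cc1`, gives 5890 nM, and compound 3, `Cc1ccc(Cc2cnc(CCc3ccc(-c4ccccc4C(=O)O)cc3)[nH]2)cc1`, gives 2660 nM. Compound 3 therefore stands second highest of the three numbers, with compound 2 as its nearest neighbour and compound 1 furthest away; the step of a 2.2-fold lower number from compound 2 to compound 3 (0.35 log units; beyond the scatter) is modest, while the step of a 15-fold higher number from compound 1 to compound 3 (1.18 log units; beyond the scatter) is large.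

The unmeasured compound 4, `O=C(O)c1ccccc1-c1ccc(CCc2ncc(Cc3cccc(F)c3F)[nH]2)cc1`, differs from compound 3 in one place: 2,3-difluorophenyl in place of 4-methylphenyl on a saturated chain carbon bound to an aromatic carbon. The ring that enters carries fluorine on two positions, one of them the position fluorinated in compound 1. Among the compounds with values here, two measured steps bear on this change. Going from compound 1 to the methylated ring cost heavily, as the step of a 15-fold higher number from compound 1 to compound 3 (1.18 log units; beyond the scatter) shows, and the nitrile analogue was costlier still, as the step of a 33-fold higher number from compound 1 to compound 2 (1.52 log units; beyond the scatter) shows. Both replacements of 2-fluorophenyl pushed the number far up, so restoring a fluorinated ring is expected to bring it back down in this assay by a large margin. The step from compound 3 to compound 4 is accordingly estimated at an 8.9-fold lower number from compound 3 to compound 4 (0.95 log units; beyond the scatter), and compound 4 is expected to give about 300 nM, within a range from 100 nM to 1000 nM.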

Compound 4, half-maximal effective concentration: 87 nM
For compound 4 the middle estimate is 3.4-fold (0.54 log units) above the measured one; the whole stated range lies above it.
By their numbers in this assay, from the lowest: compound 4; then compound 1; then compound 3; then compound 2.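

In this assay, the earlier compounds had shown only that moving away from 2-fluorophenyl on this saturated chain carbon raised the number; compound 4 shows that the number can also fall below that of compound 1, with a 2.0-fold lower number from compound 1 to compound 4 (0.31 log units; beyond the scatter) on adding one further fluoro to the ring. This step is modest, but it is beyond the scatter, and the 2,3-difluorophenyl group gives the lowest number of the four compounds, with large steps from the two non-fluorinated rings: a 31-fold lower number from compound 3 to compound 4 (1.49 log units; beyond the scatter) and a 68-fold lower number from compound 2 to compound 4 (1.83 log units; beyond the scatter). No measurement given here accounts for these differences.

The compounds shown leave open whether the gain depends on where the second fluoro sits or simply on its presence, since 2-fluorophenyl and 2,3-difluorophenyl are the only fluorinated rings here. They also leave open whether a chloro or methoxy group on the same ring would give a number close to those of compound 1 and compound 4, or one closer to those of compound 2 and compound 3, which carry a nitrile and a methyl group.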